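The source may report more compounds than this note shows. Statements on the series, on what has been measured and on what is new or still open speak of the compounds shown alone.

Measured so far in a functional assay on SW480 cells (Homo sapiens) for antiproliferative activity, read by MTT assay, with a stated time of 48 h; on this read-out higher numbers stand for weaker inhibition and lower numbers for stronger inhibition: compound 1 `O=c1cc(-n2cc(COc3cccnc3)nn2)c2cc(Br)ccc2o1` gives 39800 nM; compound 2 `COC(=O)c1ccccc1OCc1cn(-c2cc(=O)oc3ccc(Br)cc23)nn1` gives 20200 nM.

Compound 2 holds the lowest of the two numbers, but compound 1 sits within the scatter of it, so no order between the two can be claimed. Compound 3 `O=c1cc(-n2cc(COc3ccccc3Br)nn2)c2cc(Br)ccc2o1` differs from compound 2 by bromo in place of methoxycarbonyl on an aromatic carbon. Within the data shown here, no measured pair shows this change, so only a modest shift is expected, a step in this assay of about a 1.2-fold higher number from compound 2 to compound 3 (0.09 log units; within the scatter), not clearly beyond the scatter. Compound 3 is therefore estimated at 25000 nM, with a range from 8000 nM to 80000 nM.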

Compound 3, half-maximal inhibitory concentration: 20100 nM
Compound 3: the middle estimate sits 1.2-fold (0.09 log units) above what was measured; the measured number falls inside the stated range.
By their numbers in this assay, from the lowest: compounds 3, 2 and 1 (each within the scatter of the next).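

In this assay, bromo in place of methoxycarbonyl on an aromatic carbon, ortho to a large group, gives a 1.0-fold lower number from compound 2 to compound 3 (0.00 log units; within the scatter) and so shows no separable effect of this exchange at this position. 2-Bromophenyl in place of pyridin-3-yl on an oxygen on a saturated carbon gives a 2.0-fold lower number from compound 1 to compound 3 (0.30 log units; within the scatter) and likewise cannot be told from the scatter. No evidence is available to explain either result.

Going by these compounds, whether an amine or a carboxylic acid on that aromatic carbon would move the number beyond the scatter remains open.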